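The source may report more compounds than this note shows. Statements on the series, on what has been measured and on what is new or still open speak of the compounds shown alone.

Working notes on the series.

Compound 1 `N#Cc1c(N)nc(SCc2nc3ccccc3[nH]2)c(C#N)c1-c1ccc(OCC2CC2)cc1` is the starting point: in an assay on CHO cells for displacement of a labelled ligand from adenosine receptor A3 (Homo sapiens), read by scintillation counting, with a stated time of 120 min, tested at 1 uM (a higher number here means more inhibition at the concentration tested (going by the name of the read-out), a lower number less inhibition), compound 1 gives 1%. Compound 2 `N#Cc1c(N)nc(SCC2=NCCN2)c(C#N)c1-c1ccc(OCC2CC2)cc1` carries the smaller ring at the same position, and in this assay compound 2 gives 6%. Among the measured compounds shown here, the single measured step, a number 5 percentage points higher from compound 1 to compound 2 (within the scatter), is within the scatter, so the two numbers cannot be told apart; compound 2 stands with compound 1 at the low end of the read-out, and nothing in the measurements sets it apart.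

Compound 3 `N#Cc1c(N)nc(SCc2csc(N)n2)c(C#N)c1-c1ccc(OCC2CC2)cc1` is not yet measured in this assay. It differs from compound 2 in one place: a group of 6 heavy atoms (3 carbon, 2 nitrogen, 1 sulfur; one five-membered aromatic ring with 2 hetero atoms) in place of a group of 5 heavy atoms (3 carbon, 2 nitrogen; one five-membered non-aromatic ring with 2 hetero atoms), on a saturated chain carbon bound to a sulfur. For the measured compounds named here, the only step that bears on this change is the one from compound 1 to compound 2, which exchanged groups at the very same place and moved the read-out by an amount within the scatter. On that basis a step of a number 1 percentage points lower from compound 2 to compound 3 (within the scatter) is expected, that is, no change beyond the scatter in this assay. For compound 3 the expected value in this assay is 5%, with a range from 0% to 20%.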

Compound 3, a percentage reported as inhibition, at one concentration (the size of the read-out at that concentration, not a potency): 1%
Compound 3: the middle estimate sits 4 percentage points above what was measured; low and high end bracket the measured number.
By their numbers in this assay, from the lowest: compounds 1, 3 and 2 (each within the scatter of the next).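

In this assay the 2-amino-1,3-thiazol-4-yl group on a saturated chain carbon bound to a sulfur gives a number 5 percentage points lower from compound 2 to compound 3 (within the scatter) and no change at the digits printed from compound 1 to compound 3 (within the scatter) and so adds a third group to a position that until now rested on one comparison. The 1H-benzimidazol-2-yl group, the five-membered non-aromatic ring and the 2-amino-1,3-thiazol-4-yl group cannot be told apart at this place, so neither an aromatic ring in place of a non-aromatic one, nor a ring sulfur, nor a fused six-membered ring separates any of these compounds from the others in this read-out at the one concentration tested. No supporting measurement accompanies these numbers, and the reason for this flat result remains unknown.

Still open, on these data alone, is whether a group of another kind at this place, such as a simple amine, a carboxylic acid or a longer alkyl chain, would lift the read-out clear of the low end where compounds 1, 2 and 3 stand together. Also open, as far as these compounds go, is whether any change away from this place would do so, as the rest of the core is the same in all three compounds.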